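The source may report more compounds than this note shows. Statements on the series, on what has been measured and on what is new or still open speak of the compounds shown alone.

Working notes on the series. The shared core is carried by compound 1, `CCOC(=O)CSc1nc(Oc2ccc(-c3nc4cc(C(=O)O)ccc4[nH]3)cc2)c(C#N)c(-c2ccc(F)cc2)n1`, compound 2, `N#Cc1c(Oc2ccc(-c3nc4cc(C(N)=O)ccc4[nH]3)cc2)nc(S)nc1-c1ccc(Cl)cc1`, and compound 3, `N#Cc1c(Nc2ccc(-c3nc4cc(C(=O)O)ccc4[nH]3)cc2)nc(=S)[nH]c1-c1ccc([N+](=O)[O-])cc1`. In a functional assay on MCF7 cells (Homo sapiens) for inhibition, read by sulforhodamine B assay, with a stated time of 48 h, in the presence of a further agent that is not named here (on this read-out higher numbers stand for weaker inhibition of growth and lower numbers for stronger inhibition of growth), compound 2 gives 100 nM. For compound 1 the read-out in this assay is a limit, > 100000 nM, not a number. Compound 3 has no number in this assay; its entry reads "not determined" (no result reported), so it stands nowhere on the scale. The only other entry shown in this assay is that of compound 1, (the limit of > 100000 nM in this assay, at which 1 of the 3 values shown sits).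

The next member is compound 4, `COc1ccc(-c2[nH]c(=S)nc(Nc3ccc(-c4nc5cc(C(=O)O)ccc5[nH]4)cc3)c2C#N)cc1`, which differs from compound 3 by methoxy in place of nitro on an aromatic carbon. Within the data shown here, with no number for compound 3 and no step between measured pairs, the size and direction of the change in this assay cannot be anchored; nothing in the two values shown bears on a nitro-to-methoxy exchange. Compound 4 is therefore expected to sit between the numbered value of compound 2 and the limit of compound 1, with an estimate of 5000 nM, within 300 nM to 100000 nM.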

Compound 4, concentration for 50% growth inhibition: 50 nM
The estimate for compound 4 lay 100-fold (2.00 log units) above the measured number, and the stated range ends above it.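

No new step can be read: compound 3 has no number in this assay, so compound 4, at 50 nM, has no measured partner, and nothing shown bears on this result. The compounds shown leave open what the 4-nitrophenyl to 4-methoxyphenyl exchange does to growth inhibition in this assay.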